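Oxime ether series: fluoro addition on the benzyl ring

The source may hold more compounds than are shown below. What is called first, only, known or untested is meant among the compounds shown, and "the series" means these compounds.

Compound 1 `O=[N+]([O-])c1cc(C(F)(F)F)cc([N+](=O)[O-])c1Oc1ccc(Br)cc1/C=N\OCc1ccccc1` and compound 2 `O=[N+]([O-])c1cc(C(F)(F)F)cc([N+](=O)[O-])c1Oc1ccc(Br)cc1/C=N\OCc1ccccc1F` share one core; compound 3 `O=[N+]([O-])c1cc(C(F)(F)F)cc([N+](=O)[O-])c1Oc1c(Cl)cc(Cl)cc1/C=N\OCc1ccccc1` and compound 4 `O=[N+]([O-])c1cc(C(F)(F)F)cc([N+](=O)[O-])c1Oc1c(Cl)cc(Cl)cc1/C=N\OCc1ccccc1F` share another. The difference between the two cores is not broken down here. In a functional assay on HepG2 cells (Homo sapiens) for antiproliferative activity, read by MTT assay, with a stated time of 48 h (on this read-out higher numbers stand for weaker inhibition and lower numbers for stronger inhibition), compound 1 gives 1180 nM and compound 2 gives 890 nM; the change from compound 1 to compound 2 is fluoro in place of hydrogen on an aromatic carbon and the step is a 1.3-fold lower number from compound 1 to compound 2 (0.12 log units; within the scatter). In this assay compound 3 gives 1120 nM. Compound 4 carries the same change on the other core, (fluoro in place of hydrogen on an aromatic carbon). Compound 4 is expected to sit close to compound 3, with the step estimated as a 1.3-fold lower number from compound 3 to compound 4 (0.12 log units; within the scatter), because the matching change gave only a 1.3-fold lower number from compound 1 to compound 2 (0.12 log units; within the scatter). Compound 4 is therefore estimated at 850 nM, with a range from 450 nM to 1700 nM.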

Compound 4, half-maximal inhibitory concentration: 820 nM
Estimate against measurement, compound 4: 1.0-fold (0.02 log units) above; measured number inside the range.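

On the second core, benzyl to 2-fluorobenzyl gives a 1.4-fold lower number from compound 3 to compound 4 (0.14 log units; within the scatter). In this assay, the change carries from one core to the other without a detectable difference: the same change on two cores in this assay, a 1.3-fold lower number (0.12 log units; within the scatter) from compound 1 to compound 2 and a 1.4-fold lower number (0.14 log units; within the scatter) from compound 3 to compound 4, 1.0-fold (0.01 log units) apart, within the scatter of two such steps. Going by these compounds alone, both steps lie within the scatter, so the agreement shows only that this change leaves the number little moved on these two cores; it does not show a real gain in inhibition, nor that a third core would behave alike.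

Open, on these data alone, is whether methoxy, a nitrile or an amine on the benzyl ring in place of fluoro would give a step beyond the scatter. Also open, as far as these compounds go, is whether the two cores would still match for such a step.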